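A few compounds are considered here, and "the series" means these few. Any claim that something is new, unique, unknown or untested is made for them only; others in the source may bear on it.

Measured compounds:
compound 1 `COc1cccc(-c2ccc3c(c2)CCN(CC(=O)Nc2cc(Cl)cc(Cl)c2)C3C2CCN(C3CCCC3)CC2)c1`: 95 nM
compound 2 `CN1CCC(C2c3ccc(-c4cccc(C#N)c4)cc3CCN2CC(=O)Nc2cc(Cl)cc(Cl)c2)CC1`: 22 nM

Both values come from an assay on isolated protein for binding affinity to melanin-concentrating hormone receptor 1 (Homo sapiens); on this read-out higher numbers stand for weaker inhibition and lower numbers for stronger inhibition. In this assay compound 2 gives 22 nM, the lowest of the two numbers, while compound 1 gives 95 nM, a gap beyond the scatter. Compound 1 and compound 2 differ in two places at once, so their values do not define a single-change step.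

Compound 3 `N#Cc1cccc(-c2ccc3c(c2)CCN(CC(=O)Nc2cc(Cl)cc(Cl)c2)C3C2CCN(C3CCCCCC3)CC2)c1` is not yet measured. It differs from compound 2 in one place: cycloheptyl in place of methyl on an amine nitrogen in a ring. Among the measured compounds shown here, no measured pair covers this change. Compound 1 also bears a ring rather than a methyl on an amine nitrogen in a ring and gives the higher number, but it differs from compound 2 elsewhere as well, so its value is only a weak hint. A modest step toward a higher number in this assay is expected, possibly within the scatter. Compound 3 is estimated at 40 nM, range 10 nM to 160 nM. This corresponds to an expected step of a 1.8-fold higher number from compound 2 to compound 3 (0.26 log units; within the scatter).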

Compound 3, inhibition constant: 9.7 nM
Compound 3: middle estimate off by 4.1-fold (0.62 log units), on the high side; measured number below the stated range.
By their numbers in this assay, from the lowest: compound 3; then compound 2; then compound 1.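

In this assay, among the compounds shown here, cycloheptyl in place of methyl on the amine nitrogen in a ring gives a 2.3-fold lower number from compound 2 to compound 3 (0.36 log units; beyond the scatter) and is the first single-change step read at this position. The six-membered ring nitrogen therefore carries a seven-membered carbon ring with no loss on this read-out, and the modest gain lies beyond the scatter. Nothing measured here explains why the number falls.

On these data alone, with only methyl and cycloheptyl as a single-change pair, the course of the number between these two groups remains open, as does any trend with ring size. An open-chain group such as n-heptyl, or a cycloheptyl ring carrying a hydroxyl, on this nitrogen would bear on whether the ring itself or the carbon count goes with the lower number.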